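The compounds below may be only part of what the source reports. "The series", "measured", "known", "first", "only" and "open" are said of these compounds alone.

- compound 1 `CCn1c(C(=O)NCCN(C)C)ccc1C(CC)(CC)c1ccc(OCCC(O)(CC)CC)c(C)c1` gives 240 nM
- compound 2 `CCn1c(C(=O)N(CCC#N)CCC#N)ccc1C(CC)(CC)c1ccc(OCCC(O)(CC)CC)c(C)c1` gives 46300 nM

Both values come from a functional assay on HepG2 cells (Homo sapiens) for antiproliferative activity, read by MTT assay, with a stated time of 48 h; on this read-out higher numbers stand for weaker inhibition and lower numbers for stronger inhibition. Compound 2 holds the higher of the two numbers, so it is the weaker inhibitor of the pair. Among the compounds with values here, the only measured step, a 190-fold higher number from compound 1 to compound 2 (2.29 log units; beyond the scatter), changed the group on the carbonyl carbon. Compound 3 `C#CC(C)OC(=O)c1ccc(C(CC)(CC)c2ccc(OCCC(O)(CC)CC)c(C)c2)n1CC` differs at that same place: a group of 5 heavy atoms (4 carbon, 1 oxygen; no ring) in place of a group of 9 heavy atoms (6 carbon, 3 nitrogen; no ring), on a carbonyl carbon. The group entering is (1-methylprop-2-yn-1-yl)oxy, a type not yet measured here, so that single step bears on this change only indirectly. It shows that a change at this place can be large. A sizeable move toward lower numbers is expected, though smaller than that measured step, and compound 3 should remain weaker than compound 1. This expected change is a 15-fold lower number from compound 2 to compound 3 (1.19 log units; beyond the scatter). For compound 3 the estimated value is 3000 nM, with an expected range of 400 nM to 25000 nM.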

Compound 3, half-maximal inhibitory concentration: > 50000 nM
Compound 3 was reported as a limit; the forecaster's own chance of this, stated with the estimate: 8%; at least 16-fold (1.22 log units) between middle value and limit.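

Compound 3 is reported in this assay only as a limit, > 50000 nM. Within the data shown here, the step, an at least 200-fold higher number from compound 1 to compound 3 (2.31 log units; beyond the scatter), shows that (1-methylprop-2-yn-1-yl)oxy in place of (2-(dimethylamino)ethyl)amino on this carbonyl carbon also gives a large move toward weaker inhibition, so such a move is not tied to the single group that carries nitriles. The other step, an at least 1.0-fold higher number from compound 2 to compound 3 (0.03 log units; that floor lies within the scatter), allows no order between its two compounds, and it cannot be said which of the two groups is the worse replacement.

From the compounds shown here alone, how far beyond its limit compound 3 lies remains unknown. Also open, going by these compounds, is whether a carboxylic acid, or an amine on a longer chain than (2-(dimethylamino)ethyl)amino, on this carbonyl carbon would give a number near that of compound 1, 240 nM.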